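The source may report more compounds than this note shows. Statements on the series, on what has been measured and on what is new or still open speak of the compounds shown alone.

Measured so far:
compound 1 `Cc1cc(C)c(NC(=O)N(Cc2ccc(-c3n[nH]c(C)n3)cc2)C2CCCCCC2)c(C)c1` – > 1 mg/kg
compound 2 `O=C(Nc1c(F)cc(F)cc1F)N(Cc1ccc(F)cc1)Cc1cccc(-c2cc[nH]n2)c1` – < 0.32 mg/kg

In a functional assay on a cell-free system (plasma) with sterol O-acyltransferase, Soat (Rattus norvegicus) as the target (on this read-out lower numbers stand for an effect already at smaller amounts and higher numbers for an effect only at larger amounts of compound), compound 1 gives > 1 mg/kg, which is a limit of the assay and not a number, the one noted in the limit of > 1 mg/kg in this assay, at which 1 of the 2 values shown sits. Compound 2 gives < 0.32 mg/kg, again a limit, the one noted in the limit of < 0.32 mg/kg in this assay, at which 1 of the 2 values shown sits. Going by the values given here, the two values thus sit at opposite limits of this assay, and no step between them has been measured, so nothing more is said of that pair. Compound 3 `Cc1cc(C)c(NC(=O)N(Cc2ccc(-c3cccnc3)cc2)C2CCCCCC2)c(C)c1` differs from compound 1 in one place: pyridin-3-yl in place of 5-methyl-1H-1,2,4-triazol-3-yl on an aromatic carbon. Among the compounds with values here, because compound 1 stands only at the limit > 1 mg/kg, no measured step exists on which the effect of this change could rest, and its direction is open. Compound 3 is expected to come in near 1.5 mg/kg, within the range 0.5 mg/kg to 5 mg/kg. The step that the limit leaves unreadable from compound 1 to compound 3 is estimated to stay within the scatter.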

Compound 3, dose for half-maximal effect: 0.58 mg/kg
Compound 3: middle estimate off by 2.6-fold (0.41 log units), on the high side, within the range that was stated.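

Compound 1 stands in this assay at > 1 mg/kg, which is a limit of the assay and not a number. With pyridin-3-yl in place of 5-methyl-1H-1,2,4-triazol-3-yl on the aromatic carbon para to a large group, this position gains its first measured number, and the change reads as an at least 1.7-fold lower number from compound 1 to compound 3 (0.23 log units; that floor lies within the scatter). This place can therefore carry a six-membered aromatic ring with 0 hydrogen-bond donors and still give a measured value, although the step remains only a floor: the limit of > 1 mg/kg in this assay, at which 1 of the 3 values shown sits.

From the compounds shown here alone, the true size of the step cannot be read, so it stays open whether it goes beyond the scatter, and compound 2 differs from the others in more than one place. Also open, going by these compounds, is how a carboxylic acid, a primary amine or a plain phenyl ring would read at this place.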